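A few compounds are considered here, and "the series" means these few. Any claim that something is new, unique, unknown or untested is made for them only; others in the source may bear on it.

Measured so far:
Compound 1, `Cc1ccc(-c2nc(=O)o[nH]2)c(-c2ccc([C@@H](C)N(CC3CC3)c3nc4c(C(=O)O)cccc4o3)cc2)c1`: 4830 ng.h/mL
Compound 2, `CCCCN(c1nc2c(NS(C)(=O)=O)cccc2o1)[C@H](C)c1ccc(-c2ccccc2-c2nnn[nH]2)cc1`: 73.8 ng.h/mL
Compound 3, `CCCCN(c1nc2c(C(=O)O)cccc2o1)[C@H](C)c1ccc(-c2cc(F)ccc2-c2nc(=O)o[nH]2)cc1`: 1630 ng.h/mL

All three were run in an ADME assay on the whole organism (Macaca fascicularis) for pharmacokinetics, read by LC-MS, using cassette dosing, at a dose of 1 mg/kg by the oral route; on this read-out higher numbers stand for higher exposure at the dose given and lower numbers for lower exposure. Compound 2 stands lowest of the three numbers. Its nearest neighbour is compound 3, whose number is higher by a margin well beyond the usual scatter, and compound 1 stands furthest, with a number higher still. No pair among these three differs in only one place, so no single step between measured compounds can be read off, and the three cores differ in several ways at once.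

Compound 4, `CCCCN(c1nc2ccccc2o1)[C@H](C)c1ccc(-c2ccccc2-c2nnn[nH]2)cc1`, is not yet measured. Against compound 2 it shows one change: hydrogen in place of methanesulfonamido on an aromatic carbon.

Nothing measured here isolates this change, so the expectation rests only on where compound 2 stands. Because compound 2 gives 73.8 ng.h/mL, the lowest number of the set, there is more room upward than downward, and the step from compound 2 to compound 4 is estimated as a modest rise, a 2.7-fold higher number from compound 2 to compound 4 (0.43 log units; beyond the scatter), of a size that may or may not exceed the scatter. For compound 4 the expected exposure is 200 ng.h/mL, with a range from 60 ng.h/mL to 700 ng.h/mL.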

Compound 4, area under the concentration-time curve: 44.3 ng.h/mL
Compound 4: the middle estimate sits 4.5-fold (0.65 log units) above what was measured; the whole stated range lies above it.
By their numbers in this assay, from the lowest: compounds 4 and 2 (each within the scatter of the next); then compound 3; then compound 1.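

In this assay, hydrogen in place of methanesulfonamido on an aromatic carbon, ortho to a fused ring and meta to a fused ring, gives a 1.7-fold lower number from compound 2 to compound 4 (0.22 log units; within the scatter) in this pair of compounds. So for this pair, removing the whole group, together with its hydrogen-bond donor and acceptors, leaves a difference in exposure that cannot be told apart from the variation between repeated measurements, which is something no earlier comparison could show. Nothing shown here gives a reason for this result.

From the compounds shown here alone, whether an amine or a methoxy group on this same aromatic carbon, with the rest of compound 4 unchanged, would move exposure beyond that variation remains open. For the compounds shown here, compound 1 and compound 3 carry a carboxylic acid, but they differ from compound 2 and compound 4 in several places at once, so no step to them can be read and their numbers cannot be tied to that group or to any other single change.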